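Working notes on compound 4 and its three measured analogues

This account rests on a few compounds, and the source may have more. Where it says the series, first, only, none or still open, it means among the compounds named here.

Measured so far in a functional assay on A-375 cells (Homo sapiens) for antiproliferative activity, read by CCK-8 assay, with a stated time of 72 h, tested at 8 uM; on this read-out higher numbers stand for a stronger effect at the one concentration tested and lower numbers for a weaker effect:
compound 1 `Nc1ccccc1NC(=O)c1ccc(CSC(=S)N2CCc3cc([N+](=O)[O-])ccc32)cc1`, giving 29.5%
compound 2 `Nc1ccccc1NC(=O)c1ccc(CSC(=S)N2CCc3ccc([N+](=O)[O-])cc32)cc1`, giving 42%
compound 3 `Nc1ccccc1NC(=O)c1ccc(CSC(=S)N2CCN(c3ccncc3)CC2)cc1`, giving 90.7%

Compound 3 stands highest of the three numbers in this assay. Its nearest neighbour is compound 2, whose number lies below it by more than the usual scatter, and the furthest is compound 1, lower still and likewise well beyond the scatter. Among the compounds with values here, compounds 1 and 2 share a nitro-bearing bicyclic amine on the thiocarbonyl, whereas compound 3 carries a six-membered non-aromatic ring with two nitrogens bearing pyridin-4-yl; no single-point step links them, so only the values themselves can be compared.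

Compound 4 `CN1CCN(C(=S)SCc2ccc(C(=O)Nc3ccccc3N)cc2)CC1` keeps the whole of compound 3 except for one change: methyl in place of pyridin-4-yl on an amine nitrogen in a ring. Within the data shown here, no measured step of this kind exists, so the expectation rests on compound 3 alone. The six heavy atoms that leave are not replaced by anything of comparable size, and the one hydrogen-bond acceptor of the leaving group is lost. The step of a number 20.7 percentage points lower from compound 3 to compound 4 (beyond the scatter) is expected to be downward and somewhat beyond the scatter, though compound 4 should remain clearly above compounds 1 and 2. Compound 4 is therefore estimated at 70%, with a range from 45% to 90%.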

Compound 4, a percentage reported as inhibition, at one concentration (the size of the read-out at that concentration, not a potency): 91.6%
For compound 4 the middle estimate is 21.6 percentage points below the measured one; measured number above the stated range.
By their numbers in this assay, from the lowest: compound 1; then compound 2; then compounds 3 and 4 (each within the scatter of the next).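

In this assay, within the data shown here, replacing pyridin-4-yl with methyl on an amine nitrogen in a ring gives a number 0.9 percentage points higher from compound 3 to compound 4 (within the scatter); this is the first step that can be read in one place. At this position, the six-membered aromatic ring and the hydrogen-bond acceptor that leave with pyridin-4-yl are therefore not needed to keep the read-out of this assay at its one tested concentration, where a single methyl serves alike, although that read-out gives the size of the effect at that concentration and not a potency. No measurement available here offers an explanation for this result.

The compounds shown leave open how the same nitrogen responds to other groups, such as a longer alkyl chain, a chain ending in a carboxylic acid or a chain ending in a primary amine, and whether compound 3 and compound 4 would separate at other concentrations. Among these compounds, no single-place step ties compound 1 or compound 2 to the two piperazine-free comparisons of this pair, so the amine portion on the thiocarbonyl remains unresolved as a variable.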